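The compounds below may be only part of what the source reports. "The series", "measured", "known", "first", "only" and "open" are said of these compounds alone.

In a functional assay on Jurkat cells for inhibition of nuclear factor NF-kappa-B complex (Homo sapiens) (on this read-out higher numbers stand for weaker inhibition and lower numbers for stronger inhibition), compound 2 `CCOC(=O)c1cnc(-c2cccc([N+](=O)[O-])c2)nc1NN1C(=O)C=C(C)C1=O` gives 7000 nM, and compound 1 `CCOC(=O)c1cnc(-c2csc(C)n2)nc1NN1C(=O)C=C(C)C1=O` gives 8000 nM; the two values sit within the scatter of each other, so compound 2 stands level with compound 1 on the numbers shown. Among the compounds with values here, the one measured step, a 1.1-fold lower number from compound 1 to compound 2 (0.06 log units; within the scatter), shows that exchanging the group at this position left the read-out unchanged. Compound 3 `CCOC(=O)c1cnc(C(=O)c2ccco2)nc1NN1C(=O)C=C(C)C1=O` carries a different exchange at the same place: (furan-2-yl)carbonyl in place of 3-nitrophenyl on an aromatic carbon. Within the data shown here, no measured step covers this change, and the single step available was flat, so the estimated step of a 1.1-fold higher number from compound 2 to compound 3 (0.06 log units; within the scatter) is none beyond the scatter. Compound 3 is therefore expected to give 8000 nM, in the range 2500 nM to 25000 nM.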

Compound 3, half-maximal inhibitory concentration: 700 nM
Compound 3: middle estimate off by 11-fold (1.06 log units), on the high side, and the stated range ends above it.
By their numbers in this assay, from the lowest: compound 3; then compounds 2 and 1 (each within the scatter of the next).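

The position is not indifferent in this assay: placing (furan-2-yl)carbonyl there gives a 10-fold lower number from compound 2 to compound 3 (1.00 log units; beyond the scatter) and an 11-fold lower number from compound 1 to compound 3 (1.06 log units; beyond the scatter), although the exchange between 3-nitrophenyl and 2-methyl-1,3-thiazol-4-yl stayed within the scatter. Inhibition at this place can therefore be strengthened by a change of group, and the earlier flat step did not reveal this. Nothing available explains the stronger inhibition of compound 3.

The compounds shown leave open whether the carbonyl or the furan ring carries this step. Going by these compounds, how a benzoyl group or an amine would read at this place also remains open.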